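Aryl in place of propyl on the imidazole nitrogen

The compounds below may be only part of what the source reports. "The series", "measured", "known", "first", "only" and "open" are said of these compounds alone.

Measured so far in a functional assay on HeLa cells (Homo sapiens) for antiproliferative activity, read by MTT assay, with a stated time of 72 h; on this read-out higher numbers stand for weaker inhibition and lower numbers for stronger inhibition:
- compound 1, `CCCn1ccnc1-c1cc(OC)c(OC)c(OC)c1`: > 100000 nM
- compound 2, `COc1cc(-c2nccn2S(=O)(=O)c2ccc(C)cc2)cc(OC)c1OC`: > 100000 nM
- compound 3, `COc1ccc(-n2ccnc2-c2cc(OC)c(OC)c(OC)c2)cc1[N+](=O)[O-]`: 2500 nM

Compound 1 carries a propyl group on a ring nitrogen of its core. In this assay compound 1 gives > 100000 nM; this is a limit of the assay, not a number. Compound 2 also comes out at a limit, > 100000 nM. Among the measured compounds shown here, compound 3 is the only one with a number, 2500 nM. Two of the three values sit at the same place: the limit of > 100000 nM in this assay, at which 2 of the 3 values shown sit.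

Compound 4, `COc1cc(-c2nccn2-c2ccc(F)cc2)cc(OC)c1OC`, differs from compound 1 in one place: 4-fluorophenyl in place of propyl on an aromatic nitrogen. For the measured compounds named here, compound 3, the one compound with a measured number, also carries an aromatic ring on that nitrogen, while compound 1 and compound 2 do not. On that ground a step towards stronger inhibition is expected, though with a real chance of another limit. For compound 4 the estimated value is 6000 nM, between 1000 nM and 40000 nM, which would mean an expected step of an at least 16-fold lower number from compound 1 to compound 4 (1.22 log units; beyond the scatter).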

Compound 4, half-maximal inhibitory concentration: 17500 nM
Estimate against measurement, compound 4: 2.9-fold (0.46 log units) below, and the stated range covers the measured number.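

In this assay, 4-fluorophenyl in place of propyl on the aromatic nitrogen gives an at least 5.7-fold lower number from compound 1 to compound 4 (0.75 log units; beyond the scatter). Among the compounds shown here, this is the first comparison in which a single change at this nitrogen can be read, and it shows that the position responds to what it carries, with an aromatic ring here compatible with a measurable number. The true size of the step stays unknown, because the value of compound 1 is a limit of the assay and not a number: the limit of > 100000 nM in this assay, at which 2 of the 4 values shown sit.

The compounds shown leave open whether the fluorine contributes anything beyond what a plain phenyl ring would give. They also leave open whether a benzyl group, a longer chain or an amine on this nitrogen would lower the number as well.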